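Swapping one five-membered ring for another on the sigma-1 core

The source may report more compounds than this note shows. Statements on the series, on what has been measured and on what is new or still open speak of the compounds shown alone.

Measured so far:
compound 1 `Clc1ccccc1-c1ncnc2c1cnn2CCN1CCCCC1`: 76 nM
compound 2 `c1nc(-c2cnsc2)c2cnn(CCN3CCCCC3)c2n1`: 475 nM

Going by the values given here, in an assay on HEK293 cells for displacement of a labelled ligand from Sigma non-opioid intracellular receptor 1 (Homo sapiens), read by scintillation counting, with a stated time of 120 min (a lower number here means a stronger inhibitor, a higher number a weaker inhibitor), compound 2 gives the higher of the two numbers, the weaker binder; the only measured step, a 6.3-fold higher number from compound 1 to compound 2 (0.80 log units; beyond the scatter), is the one that leads to it. Compound 3 `Cn1cnc(-c2ncnc3c2cnn3CCN2CCCCC2)c1` differs from compound 2 by 1-methyl-1H-imidazol-4-yl in place of 1,2-thiazol-4-yl on an aromatic carbon. Among the compounds with values here, no measured step trades one five-membered ring for another, so that single step is only a loose guide. Compound 3 is therefore expected to give roughly 600 nM in this assay, with a range from 150 nM to 2500 nM, meaning a 1.3-fold higher number from compound 2 to compound 3 (0.10 log units; within the scatter), a step that may well stay within the scatter.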

Compound 3, inhibition constant: 11800 nM
Beside the measured number, compound 3's estimate is 20-fold (1.29 log units) below it, and the stated range ends below it.
By their numbers in this assay, from the lowest: compound 1; then compound 2; then compound 3.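

In this assay, this position on the shared core clearly tells apart two five-membered aromatic rings with 2 hetero atoms: 1-methyl-1H-imidazol-4-yl in place of 1,2-thiazol-4-yl gives a 25-fold higher number from compound 2 to compound 3 (1.40 log units; beyond the scatter) in the direction of weaker binding. Set against 2-chlorophenyl, the same group gives a 160-fold higher number from compound 1 to compound 3 (2.19 log units; beyond the scatter) and so the widest gap in this small set. Nothing available explains this loss. Still open, from the compounds shown here alone, is whether the methyl group or the imidazole ring itself accounts for it. A 1H-imidazol-4-yl group without the methyl, or a plain phenyl ring, would help to separate these.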